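The compounds below may be only part of what the source reports. "The series", "measured", "known", "first", "only" and "open" are said of these compounds alone.

Measured so far:
compound 1 `CCN(c1nc(C)cc(C)n1)c1ccc(N(C)C)cc1C` — 54 nM
compound 2 `CCCN(CCC#N)c1nc(C)nc(N(CC)c2ccc(N(C)C)cc2C)n1` — 7 nM
compound 3 `CCN(c1nc(C)cc(C)n1)c1ccc(C(C)(C)C)cc1Br` — > 100 nM

Three compounds share a dialkylamino-substituted aryl group attached through an ethyl-bearing nitrogen to a heteroaromatic core. In an assay on isolated protein for binding affinity to corticotropin-releasing factor receptor 1 (Homo sapiens) (a lower number here means a stronger inhibitor, a higher number a weaker inhibitor), compound 1 gives 54 nM. Compound 2 carries a different core and a (2-cyanoethyl)(propyl)amino group, and in this assay compound 2 gives 7 nM, the lowest of the two numbers shown, with compound 1 as its nearest neighbour. For compound 3 this assay returns only a limit, > 100 nM, not a number.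

Compound 4 `CCCN(CCC)c1nc(C)nc(N(CC)c2ccc(N(C)C)cc2C)n1` is not yet measured. It differs from compound 2 by methyl in place of cyano on a saturated chain carbon, two bonds along the chain from a nitrogen on an aromatic ring, so that the (2-cyanoethyl)(propyl)amino group becomes dipropylamino. Going by the values given here, no measured pair in this set follows that change, so no step size can be read off. The change is expected to shift the value little, perhaps a small gain in this assay. Compound 4 is estimated at 5 nM, within 1.5 nM to 20 nM, a step of a 1.4-fold lower number from compound 2 to compound 4 (0.15 log units; within the scatter) expected from compound 2.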

Compound 4, inhibition constant: 7 nM
For compound 4 the middle estimate is 1.4-fold (0.15 log units) below the measured one, within the range that was stated.
By their numbers in this assay, from the lowest: compounds 2 and 4 (each within the scatter of the next); then compound 1. At a limit, above all of these: compound 3.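

In this assay, going by these compounds alone, the exchange of methyl for cyano on a saturated chain carbon, two bonds along the chain from a nitrogen on an aromatic ring, gives no change at the digits printed from compound 2 to compound 4 (within the scatter) and provides the first pair in this set that differs in one place. At this position the nitrile is therefore not required to hold the value, and the dipropylamino group serves as well as the (2-cyanoethyl)(propyl)amino group. The data shown offer no explanation for why this change leaves the value in place.

As far as these compounds go, it remains open whether a hydroxyl, an amine or a carboxylic acid at this chain end, or a longer chain such as butyl, would also leave the value in place. This single pair also cannot show whether the same exchange would behave alike on a different core.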